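Trifluoromethyl for Methyl on the Sulfonyl Ring

The compounds below may be only part of what the source reports. "The series", "measured", "known", "first", "only" and "open" are said of these compounds alone.

Measured so far:
compound 1 `CCn1cc(C(=O)O)c(=O)c2cc(F)c(N3CCN(C(=N)NS(=O)(=O)c4ccc(C)cc4)CC3)cc21`, giving 43 nM in a functional assay on HL-60 cells (Homo sapiens) for antiproliferative activity, read by MTT assay, with a stated time of 72 h; a lower number here means a stronger inhibitor, a higher number a weaker inhibitor
compound 2 `Cc1ccc(S(=O)(=O)NC(=N)N2CCN(c3cc4c(cc3F)c(=O)c(C(=O)O)cn4C3CC3)CC2)cc1`, giving 43 nM in this assay

Compound 2 stands level with compound 1, since the step of no change at the digits printed from compound 1 to compound 2 (within the scatter) lies within the scatter. Compound 3 `N=C(NS(=O)(=O)c1ccc(C(F)(F)F)cc1)N1CCN(c2cc3c(cc2F)c(=O)c(C(=O)O)cn3C2CC2)CC1` differs from compound 2 by trifluoromethyl in place of methyl on an aromatic carbon, the change sitting on an aromatic carbon of a six-membered aromatic ring of carbon only. Going by the values given here, the single measured step concerns a different part of the shared core and showed no movement, so no step bears on this change. With nothing pointing either way, compound 3 is expected to stay close to compound 2; the estimated step is a 1.0-fold higher number from compound 2 to compound 3 (0.02 log units; within the scatter). In this assay compound 3 is estimated at 45 nM, from 18 nM to 110 nM.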

Compound 3, half-maximal inhibitory concentration: 43 nM
Beside the measured number, compound 3's estimate is 1.0-fold (0.02 log units) above it; low and high end bracket the measured number.
By their numbers in this assay, from the lowest: compounds 1, 2 and 3 (each within the scatter of the next).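

In this assay, going from 4-methylphenyl to 4-(trifluoromethyl)phenyl gives no change at the digits printed from compound 2 to compound 3 (within the scatter). Going by these compounds alone, the earlier step touched only the group on the aromatic nitrogen, so this is the first evidence about the sulfonyl ring: here, its methyl can give way to the larger trifluoromethyl with no visible effect on the read-out. No supporting measurement explains this flat result.

The compounds shown leave open whether this position would stay as undemanding with an amine or a carboxylic acid in place of trifluoromethyl.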